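The source may hold more compounds than are shown below. What is called first, only, known or untested is meant among the compounds shown, and "the series" means these compounds.

Working notes on the shared core. Compound 1 `C[C@@H](Nc1c(C(=O)NCc2ccc(F)cc2)nc(Br)c2cccnc12)c1ccccc1` carries a 1-phenylethyl on a nitrogen on an aromatic ring. In a functional assay on HCT-116 cells (Homo sapiens) for cytotoxicity, read by MTT assay, with a stated time of 72 h (a lower number here means a stronger inhibitor, a higher number a weaker inhibitor), compound 1 reaches only the assay limit, > 20000 nM. Compound 3 `C[C@H](Nc1c(C(=O)NCc2ccc(F)cc2)nc(Br)c2cccnc12)c1ccccc1` has the same atoms and bonds as compound 1 and differs only in configuration as drawn. In this assay compound 3 also gives only a limit, > 20000 nM. Compound 2 `Nc1ccc(Nc2c(C(=O)NCc3ccc(F)cc3)nc(Br)c3cccnc23)cc1` bears 4-aminophenyl in place of 1-phenylethyl, and in this assay compound 2 gives 7000 nM. So compound 3 stands at the limit, with compound 1, and the step that the two limits leave unreadable from compound 1 to compound 3 cannot be sized because of the limit of > 20000 nM in this assay, at which 2 of the 3 values shown sit. Within the data shown here, the one readable step that touches compound 3 is an at least 2.8-fold higher number from compound 2 to compound 3 (0.45 log units; beyond the scatter), and its mirror is an at least 2.8-fold lower number from compound 1 to compound 2 (0.45 log units; beyond the scatter).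

Compound 4 `O=C(NCc1ccc(F)cc1)c1nc(Br)c2cccnc2c1NCc1ccccc1` is the next step: hydrogen in place of methyl on a saturated chain carbon bound to an aromatic carbon and a nitrogen on an aromatic ring. Benzylamino sits nearer to the (1-phenylethyl)amino of compound 3 than to the 4-aminophenyl of compound 2, and nothing among the measured steps separates a methyl on that saturated chain carbon from hydrogen. The expectation is therefore a step of a number no higher from compound 3 to compound 4 (the limit leaves the size open) that stays within the scatter, with a fair chance that only a limit is again reported. Compound 4 is estimated at 20000 nM, in the range 6000 nM to 60000 nM.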

Compound 4, half-maximal inhibitory concentration: > 20000 nM
Compound 4 ended at the assay's limit; the forecaster's own chance of this, stated with the estimate: 55%; the middle value lies on the limit itself.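

In this assay compound 4 gives only a limit (> 20000 nM), so hydrogen in place of methyl on this saturated chain carbon brings no value into the readable range. The steps from compound 1 and from compound 3 to compound 4 cannot be read: (the limit of > 20000 nM in this assay, at which 3 of the 4 values shown sit). Benzyl in place of 4-aminophenyl on a nitrogen on an aromatic ring gives an at least 2.8-fold higher number from compound 2 to compound 4 (0.45 log units; beyond the scatter) and leaves compound 2 the only one of the four with a number and not a limit.

The compounds shown do not separate the amino group of compound 2 from its phenyl ring, a question that plain phenyl or 4-hydroxyphenyl on that nitrogen would address. Neither the methyl nor its configuration can be sized while compound 1, compound 3 and compound 4 stay at the limit.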